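A few compounds are considered here, and "the series" means these few. Any claim that something is new, unique, unknown or untested is made for them only; others in the source may bear on it.

In a functional assay on MDA-MB-468 cells (Homo sapiens) for cytotoxicity, with a stated time of 48 h (a higher number here means a weaker inhibitor, a lower number a stronger inhibitor), compound 1 `COc1ccc(-c2cc(COC(Cc3cn(C4CCN(Cc5ccc([N+](=O)[O-])cc5)CC4)nn3)c3ccc(Br)cc3)on2)cc1` gives 9000 nM. Compound 2 `COc1cccc(-c2cc(COC(Cc3cn(C4CCN(Cc5ccc([N+](=O)[O-])cc5)CC4)nn3)c3ccc(Br)cc3)on2)c1` shows only a limit of the assay, > 25000 nM. Compound 3 `N#Cc1cccc(-c2cc(COC(Cc3cn(C4CCN(Cc5ccc([N+](=O)[O-])cc5)CC4)nn3)c3ccc(Br)cc3)on2)c1` likewise shows only a limit, > 25000 nM. Compound 3 thus stands at the limit of > 25000 nM in this assay, at which 2 of the 3 values shown sit, so its true number is not known, only the edge it lies beyond.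

The step to compound 4 `COc1ccccc1-c1cc(COC(Cc2cn(C3CCN(Cc4ccc([N+](=O)[O-])cc4)CC3)nn2)c2ccc(Br)cc2)on1` is the change (2-methoxyphenyl in place of 3-cyanophenyl on an aromatic carbon). Within the data shown here, two measured steps bear on it. The step of an at least 2.7-fold higher number from compound 1 to compound 3 (0.44 log units; beyond the scatter) shows that trading 4-methoxyphenyl for 3-cyanophenyl weakened the compound. The step that the two limits leave unreadable from compound 2 to compound 3 cannot be read, as both its ends are limits. Among the measured compounds shown here, the 2-methoxyphenyl of compound 4 carries the methoxy seen in compound 1, yet in a placement that no measured compound has, so whether compound 4 behaves more like compound 1 or like compounds 2 and 3 remains open.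

Compound 4 is therefore expected to give about 20000 nM, with a likely range from 7000 nM to 60000 nM. Against compound 3 this estimate means an expected step of an at least 1.2-fold lower number from compound 3 to compound 4 (0.09 log units; that floor lies within the scatter), which may again end in a limit rather than a number.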

Compound 4, half-maximal inhibitory concentration: > 25000 nM
Compound 4: no number, only a limit; the forecaster's own chance of this, stated with the estimate: 50%; middle value at least 1.2-fold (0.09 log units) from the limit.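

In this assay, 2-methoxyphenyl in place of 4-methoxyphenyl gives an at least 2.7-fold higher number from compound 1 to compound 4 (0.44 log units; beyond the scatter). Among the three methoxyphenyl compounds shown, only the 4-methoxyphenyl of compound 1 gives a number rather than a limit, so the place of the methoxy on this phenyl ring matters at this position on the five-membered ring. The steps from compound 2 and from compound 3 to compound 4 cannot be read, as both ends of each are limits, and the new result adds to the group of compounds resting at the same limit: the limit of > 25000 nM in this assay, at which 3 of the 4 values shown sit.

From the compounds shown here alone, how far compound 2, compound 3 and compound 4 lie beyond that limit stays unknown. Also open, going by these compounds, is whether another group in the place of the methoxy of compound 1, such as a hydroxyl, an amine or a chlorine, would match or improve on compound 1.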